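Butylsulfanyl for hexyloxy, starting from a limit

The source may report more compounds than this note shows. Statements on the series, on what has been measured and on what is new or still open speak of the compounds shown alone.

In an ADME assay on Akata cells (Homo sapiens) for cytotoxicity, with a stated time of 7 days (a higher number here means that more compound is tolerated, a lower number that less compound is tolerated), compound 1 `Nc1nc(NC2CC2)c2ncn(/C=C3/CC3(CO)CO)c2n1` shows > 20000 nM and this is a limit. In the same read-out compound 2 `CCCCCCOc1nc(N)nc2c1ncn2/C=C1/CC1(CO)CO` shows > 20000 nM and this too is a limit. Within the data shown here, compound 2 therefore has no number of its own, and the whole series so far stands at the limit of > 20000 nM in this assay, at which 2 of the 2 values shown sit, and nowhere else.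

Compound 3 `CCCCSc1nc(N)nc2c1ncn2/C=C1/CC1(CO)CO` keeps the shared core and carries butylsulfanyl in place of hexyloxy on an aromatic carbon, next to the ring nitrogen: butylsulfanyl in place of hexyloxy on an aromatic carbon is the full difference.

Among the measured compounds shown here, the one measured step is a step that the two limits leave unreadable from compound 1 to compound 2 and it offers no size to carry over. The expectation therefore rests only on compound 2 at > 20000 nM as a limit, and on compound 1 sitting at the same limit after a different change at this carbon. No shift beyond the scatter is expected in this assay and no direction can be argued. The expected step is a number no higher from compound 2 to compound 3 (the limit leaves the size open) on this reading, and a report of a limit alone is the likeliest outcome. Compound 3 is estimated at 20000 nM with an expected range from 7000 nM to 40000 nM in this estimate.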

Compound 3, half-maximal cytotoxic concentration: > 20000 nM
Compound 3: a limit, no number (the forecaster's own chance of this, stated with the estimate: 70%); the middle value lies on the limit itself.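

In this assay compound 3 gives > 20000 nM, which is a limit, so its steps from compound 1 and compound 2 cannot be read. The series stays at a single limit: the limit of > 20000 nM in this assay, at which 3 of the 3 values shown sit. The compounds shown leave open whether cyclopropylamino, hexyloxy and butylsulfanyl on this aromatic carbon differ at all in the concentration tolerated.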